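The compounds below may be only part of what the source reports. "The series", "measured", "known", "first", "only" and "open" are said of these compounds alone.

The compounds here share a core in which a thiourea carries a nitrophenyl group on one side and, through a short chain, a sulfonamide joined to a thiophene bearing a benzyloxyphenyl arm. Compound 1 `O=[N+]([O-])c1ccc(NC(=S)NCCNS(=O)(=O)c2ccc(-c3ccccc3OCc3ccccc3)s2)cc1` carries a 4-nitrophenyl group. In a functional assay on HL-60 cells (Homo sapiens) for inhibition, read by CCK-8 assay, with a stated time of 48 h (on this read-out lower numbers stand for stronger inhibition and higher numbers for weaker inhibition), compound 1 gives a value of > 50000 nM, which is a limit of the assay rather than a number. Compound 2 `O=[N+]([O-])c1cccc(NC(=S)NCCNS(=O)(=O)c2ccc(-c3ccccc3OCc3ccccc3)s2)c1` differs from compound 1 by 3-nitrophenyl in place of 4-nitrophenyl on an amide-type nitrogen. In this assay compound 2 also gives > 50000 nM, again a limit of the assay. The step that the two limits leave unreadable from compound 1 to compound 2 therefore cannot be read, because the limit of > 50000 nM in this assay, at which 2 of the 3 values shown sit, hides where either compound truly sits. Compound 3 `O=[N+]([O-])c1ccc(NC(=S)NCCNS(=O)(=O)c2ccc(-c3ccccc3OCc3cccc(O)c3)s2)cc1` differs from compound 1 by hydroxy in place of hydrogen on an aromatic carbon. In this assay, within the data shown here, compound 3 gives 10800 nM, the only number in the set, and the step of an at least 4.6-fold lower number from compound 1 to compound 3 (0.66 log units; beyond the scatter) shows the change toward a hydroxy-bearing compound as at least modest.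

Compound 4 `O=[N+]([O-])c1cccc(NC(=S)NCCNS(=O)(=O)c2ccc(-c3ccccc3OCc3cccc(O)c3)s2)c1` has not yet been measured in this assay. It differs from compound 3 by 3-nitrophenyl in place of 4-nitrophenyl on an amide-type nitrogen, the same change that separates compound 1 from compound 2, made at the same place on the core. The cores of compound 3 and compound 4 differ from those of compound 1 and compound 2 by hydroxy in place of hydrogen on an aromatic carbon. Since the earlier instance of this change is unreadable, with both compounds at a limit, the expected step of a 1.4-fold higher number from compound 3 to compound 4 (0.14 log units; within the scatter) for compound 4 is small and uncertain. Compound 4 is estimated at 15000 nM, within a range from 5000 nM to 50000 nM.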

Compound 4, half-maximal inhibitory concentration: 11400 nM
The estimate for compound 4 lay 1.3-fold (0.12 log units) above the measured number, and the stated range covers the measured number.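

On the hydroxy-bearing core, 3-nitrophenyl in place of 4-nitrophenyl on the amide-type nitrogen gives a 1.1-fold higher number from compound 3 to compound 4 (0.02 log units; within the scatter), so this assay does not tell these two compounds apart. Carrying the hydroxy change onto the core with the 3-nitrophenyl group gives an at least 4.3-fold lower number from compound 2 to compound 4 (0.64 log units; beyond the scatter), which lies beyond the scatter in the same direction as on the core with the 4-nitrophenyl group, although each size is only a minimum: the same change on two cores in this assay, an at least 4.6-fold lower number (0.66 log units; beyond the scatter) from compound 1 to compound 3 and an at least 4.3-fold lower number (0.64 log units; beyond the scatter) from compound 2 to compound 4; the limit leaves it open whether they differ This shows that the hydroxy change lowers the number on both of these cores, but it does not show how large the change truly is on either one, and the nitrophenyl step between the two compounds without the hydroxy group cannot be read, since those compounds sit at a limit: the limit of > 50000 nM in this assay, at which 2 of the 4 values shown sit.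

The compounds shown leave open whether a methoxy group or an amine in place of the hydroxy group would also lower the number. They also leave open what a carboxylic acid in place of the nitro group, or a longer chain between the thiourea and the sulfonamide, would do in this assay.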